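Chain swaps on an aromatic nitrogen: working notes

A few compounds are considered here, and "the series" means these few. Any claim that something is new, unique, unknown or untested is made for them only; others in the source may bear on it.

- compound 1 `CCCn1cc(C(=O)O)c(=O)c2c(O)c(Cc3cccc(Cl)c3F)ccc21` gives 24200 nM
- compound 2 `CCCCn1cc(C(=O)O)c(=O)c2c(O)c(Cc3cccc(Cl)c3F)ccc21` gives 20000 nM
- compound 3 `CCC(C)n1cc(C(=O)O)c(=O)c2c(O)c(Cc3cccc(Cl)c3F)ccc21` gives 30700 nM

All three values come from an ADME assay on C8166 cells (Homo sapiens) for cytotoxicity, read by MTT assay (a higher number here means that more compound is tolerated, a lower number that less compound is tolerated), and all three compounds differ only in the chain on an aromatic nitrogen. Compound 3 sits within the scatter of both others, with a 1.3-fold higher number from compound 1 to compound 3 (0.10 log units; within the scatter) and a 1.5-fold higher number from compound 2 to compound 3 (0.19 log units; within the scatter) as its two steps. Also within the scatter is a 1.2-fold lower number from compound 1 to compound 2 (0.08 log units; within the scatter) in this small set.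

Compound 4 `CC(C)[C@@H](CO)n1cc(C(=O)O)c(=O)c2c(O)c(Cc3cccc(Cl)c3F)ccc21` carries 1-(hydroxymethyl)-2-methylpropyl in place of sec-butyl on an aromatic nitrogen, a change of 1-(hydroxymethyl)-2-methylpropyl in place of sec-butyl on an aromatic nitrogen relative to compound 3. The three measured steps bear on this change only as swaps among simple chains. Among the measured compounds shown here, no measured compound carries 1-(hydroxymethyl)-2-methylpropyl, so the expectation remains loose. In this assay the expected step is a 1.1-fold lower number from compound 3 to compound 4 (0.04 log units; within the scatter) and nothing beyond the scatter. For compound 4 the estimated value is 28000 nM with 12000 nM to 65000 nM as the expected range.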

Compound 4, half-maximal cytotoxic concentration: 125000 nM
Compound 4: the middle estimate sits 4.5-fold (0.65 log units) below what was measured; measured number outside the range, above it.
By their numbers in this assay, from the lowest: compounds 2, 1 and 3 (each within the scatter of the next); then compound 4.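

In this assay, the chain on the aromatic nitrogen can shift the number beyond the scatter, which propyl, butyl and sec-butyl did not do among themselves: 1-(hydroxymethyl)-2-methylpropyl gives a 4.1-fold higher number from compound 3 to compound 4 (0.61 log units; beyond the scatter), a 5.2-fold higher number from compound 1 to compound 4 (0.71 log units; beyond the scatter) and a 6.3-fold higher number from compound 2 to compound 4 (0.80 log units; beyond the scatter). All three steps run in the same direction, so compound 4 stands apart from all three simple-chain compounds, with more compound tolerated. No measurement on hand accounts for this separation.

The entering chain differs from sec-butyl in size, in its hydrogen-bond donor and acceptor and in its defined stereocentre, and the compounds shown do not separate these features. On these data alone, it remains open whether a 1,2-dimethylpropyl chain, an aminomethyl analogue or the opposite stereoisomer would keep the higher number.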